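A few compounds are considered here, and "the series" means these few. Any claim that something is new, unique, unknown or untested is made for them only; others in the source may bear on it.

Working notes on the series. In a functional assay on HT-29 cells (Homo sapiens) for cytotoxicity, read by MTT assay, with a stated time of 72 h (on this read-out higher numbers stand for weaker inhibition and lower numbers for stronger inhibition), compound 3 `Cc1c(C(=O)Nc2ccc(Oc3ccnc4[nH]ccc34)cc2)nnn1-c1ccc(F)cc1` gives 180 nM. Compound 1 `Cc1c(C(=O)Nc2ccc(Oc3ccnc4[nH]ccc34)c(F)c2)nnn1-c1ccc(F)cc1` gives 120 nM in this assay and compound 2 `Cc1c(C(=O)Nc2ccc(Oc3ccnc4[nH]ccc34)cc2)nnn1-c1ccccc1F` gives 360 nM there; both of these numbers lie within the usual scatter of the number for compound 3, so no ordering among the three compounds is claimed. The step of a 1.5-fold higher number from compound 1 to compound 3 (0.18 log units; within the scatter) concerns a fluoro on an aromatic carbon; the step of a 2.0-fold lower number from compound 2 to compound 3 (0.30 log units; within the scatter) concerns the phenyl carried by the aromatic nitrogen of the five-membered aromatic ring with 3 nitrogen.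

Compound 4 `Cc1c(C(=O)Nc2ccc(Oc3ccnc4[nH]ccc34)cc2)nnn1-c1ccc(Cl)c(C(F)(F)F)c1` has not been measured. It differs from compound 3 in one place: 4-chloro-3-(trifluoromethyl)phenyl in place of 4-fluorophenyl on an aromatic nitrogen. The entering group sits on an aromatic nitrogen of the five-membered aromatic ring with 3 nitrogen, next to the ring atom that bears a methyl group. Among the compounds with values here, both measured steps touch the same phenyl and both stayed within the scatter, but neither brings in a chloro or a trifluoromethyl, so there is no direct precedent for this change. The expectation is therefore a step of a 1.1-fold higher number from compound 3 to compound 4 (0.05 log units; within the scatter) with no clear direction and a wide range. Compound 4 is estimated at 200 nM in this assay, expected to fall within 60 nM to 700 nM.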

Compound 4, half-maximal inhibitory concentration: 3290 nM
Beside the measured number, compound 4's estimate is 16-fold (1.22 log units) below it; the whole stated range lies below it.
By their numbers in this assay, from the lowest: compounds 1, 3 and 2 (each within the scatter of the next, the first and the last beyond it); then compound 4.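

At the phenyl on the aromatic nitrogen of the five-membered aromatic ring with 3 nitrogen, moving between the two fluorophenyl groups stayed within the scatter, which gave no sign of how far this position could be changed. In this assay, 4-chloro-3-(trifluoromethyl)phenyl gives an 18-fold higher number from compound 3 to compound 4 (1.26 log units; beyond the scatter), and against the other fluorophenyl it gives a 9.1-fold higher number from compound 2 to compound 4 (0.96 log units; beyond the scatter); both steps lie beyond the scatter, so the number at this position does respond to what the phenyl carries, whichever of the two fluorophenyl compounds serves as the reference. Nothing available explains the size of these steps, and the change brings in chloro and trifluoromethyl together, so the compounds cannot divide the effect between them.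

Still open, going by these compounds, is whether a phenyl carrying the chloro alone or the trifluoromethyl alone would account for most of the step, or whether only the two together produce it. Also open, on these data alone, is how a group of another kind on this phenyl, such as an amine or a carboxylic acid, would read in this assay.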